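The source may hold more compounds than are shown below. What is called first, only, known or untested is meant among the compounds shown, and "the series" means these compounds.

Compound 1 `Oc1ccc(-c2cc(-c3ccccc3F)cc(-c3cccc(O)c3)n2)cc1` in a functional assay on DU-145 cells (Homo sapiens) for inhibition (a lower number here means a stronger inhibitor, a higher number a weaker inhibitor), gives 3160 nM. Compound 2 `Oc1ccc(-c2cc(-c3cccc(C(F)(F)F)c3)cc(-c3ccccc3O)n2)cc1` gives in this assay only a limit, > 50000 nM. Compound 3 `Oc1cccc(-c2cc(-c3cccc(C(F)(F)F)c3)cc(-c3cccc(O)c3)n2)c1` gives in this assay only a limit as well, > 50000 nM.

Compound 3 therefore stands at the bound of the assay without a number of its own, and it shares that position with one other compound (the limit of > 50000 nM in this assay, at which 2 of the 3 values shown sit). Compound 4 `Oc1ccc(-c2cc(-c3cccc(C(F)(F)F)c3)cc(-c3cccc(O)c3)n2)cc1` differs from compound 3 by 4-hydroxyphenyl in place of 3-hydroxyphenyl on an aromatic carbon. For the measured compounds named here, no step between two measured compounds matches this change. Compound 4 shares both hydroxyphenyl groups with compound 1, which gives 3160 nM. A moderate gain from compound 3 is expected, an at least 2.5-fold lower number from compound 3 to compound 4 (0.39 log units; beyond the scatter), although a further limit remains nearly as likely. Compound 4 is estimated at 20000 nM, with a range from 3000 nM to 60000 nM.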

Compound 4, half-maximal inhibitory concentration: 11100 nM
Estimate against measurement, compound 4: 1.8-fold (0.26 log units) above; the measured number falls inside the stated range.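

In this assay, 4-hydroxyphenyl in place of 3-hydroxyphenyl next to the ring nitrogen gives an at least 4.5-fold lower number from compound 3 to compound 4 (0.65 log units; beyond the scatter), and 3-hydroxyphenyl in place of 2-hydroxyphenyl gives an at least 4.5-fold lower number from compound 2 to compound 4 (0.65 log units; beyond the scatter). With 3-(trifluoromethyl)phenyl in place, compound 4 is therefore the only compound shown that has a measured number rather than a limit: the limit of > 50000 nM in this assay, at which 2 of the 4 values shown sit. Its hydroxyphenyl pair is shared with compound 1, and 3-(trifluoromethyl)phenyl in place of 2-fluorophenyl gives a 3.5-fold higher number from compound 1 to compound 4 (0.55 log units; beyond the scatter).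

From the compounds shown here alone, the full size of the first two steps remains open, as both start from a limit. Also open, going by these compounds, is whether an amine or a carboxylic acid could replace either hydroxyl group.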